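This account rests on a few compounds, and the source may have more. Where it says the series, first, only, none or still open, it means among the compounds named here.

Values in a functional assay on SK-OV-3 cells (Homo sapiens) for antiproliferative activity, read by MTT assay, with a stated time of 24 h (a lower number here means a stronger inhibitor, a higher number a weaker inhibitor), for the three measured compounds:

Compound 1 `COc1ccc(C(=O)/C=C/c2cccc(F)c2)c2c1C=CC(C)(C)O2`: > 10000 nM
Compound 2 `COc1ccc(C(=O)/C=C/c2ccc(N(c3ccccc3)c3ccccc3)cc2)c2c1C=CC(C)(C)O2`: > 10000 nM
Compound 3 `COc1ccc(C(=O)/C=C/c2cccc3ccccc23)c2c1C=CC(C)(C)O2`: > 10000 nM

Each of these three values is a limit of this assay rather than a measured number. Compound 1 therefore gives no number of its own, only a limit. Compound 2 likewise stands at a limit. Compound 3 stands at the same limit. Together they define (the limit of > 10000 nM in this assay, at which 3 of the 3 values shown sit), so nothing in the measured set separates one compound from another, and no ordering can be drawn among them.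

Compound 4 `COc1ccc(C(=O)/C=C/c2cccc(Cl)c2)c2c1C=CC(C)(C)O2` is the unmeasured compound. It differs from compound 1 in one place: chloro in place of fluoro on an aromatic carbon. Without any measured step among the compounds, the step is expected to stay within the scatter, and the estimate for compound 4 therefore rests on the limit at which compound 1 sits. Because all three known values sit at the limit of > 10000 nM in this assay, at which 3 of the 3 values shown sit, compound 4 is expected to give 12000 nM, with a range of 4000 nM to 40000 nM. The step implied by this estimate is a step that the limit leaves unreadable from compound 1 to compound 4, and it is expected to be no more than the scatter in this assay, with a real chance that only a limit is reported again.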

Compound 4, half-maximal inhibitory concentration: > 10000 nM
Compound 4 was reported as a limit; the forecaster's own chance of this, stated with the estimate: 70%; the middle value is on the limit's open side.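

In this assay compound 4 gives > 10000 nM, which is a limit and not a number. Compound 1 also stands at a limit, so no step can be read between compound 1 and compound 4. The compounds shown leave open how any of them ranks against the others, because all share one limit: the limit of > 10000 nM in this assay, at which 4 of the 4 values shown sit.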